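Chloro to isopropoxy at the limit of the assay

This account rests on a few compounds, and the source may have more. Where it says the series, first, only, none or still open, it means among the compounds named here.

In an ADME assay on PA-1 cells (Homo sapiens) for cytotoxicity, read by MTT assay, with a stated time of 72 h (on this read-out higher numbers stand for weaker inhibition and lower numbers for stronger inhibition), compound 1 (`COc1ccc(C2=C(c3cc(OC)c(OC)c(OC)c3)C(=O)C(O)C2)cc1Cl`) gives > 100 ug/mL as a limit and not a number. Compound 2 (`COc1ccc(C2=C(c3cc(OC)c(OC)c(OC)c3)C(=O)C(OC(C)=O)C2)cc1Cl`) also gives only a limit, > 100 ug/mL in this case. Compound 3 (`CC(=O)OC1C/C(=N/O)C(c2ccccc2)=C1c1ccccc1`) likewise gives > 100 ug/mL as a limit. Everything so far is therefore the limit of > 100 ug/mL in this assay, at which 3 of the 3 values shown sit, and no true number is available as a starting point.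

Compound 4 (`COc1ccc(C2=C(c3cc(OC)c(OC)c(OC)c3)C(=O)C(O)C2)cc1OC(C)C`) keeps the core of compound 1 and changes one group: isopropoxy in place of chloro on an aromatic carbon is the whole difference, isopropoxy in place of chloro on an aromatic carbon.

For the measured compounds named here, the only measured step is a step that the two limits leave unreadable from compound 1 to compound 2 and it concerns acetyl in place of hydrogen on an oxygen on a saturated carbon, not this aromatic carbon. It therefore sets no size for the new change, and no readable shift in either direction is expected in this assay here. The expected step is a step that the limit leaves unreadable from compound 1 to compound 4 and the most likely report is another limit. Compound 4 is estimated at 130 ug/mL with 50 ug/mL to 300 ug/mL as the expected range.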

Compound 4, half-maximal inhibitory concentration: > 100 ug/mL
Compound 4 was reported as a limit; the forecaster's own chance of this, stated with the estimate: 75%; the middle value is on the limit's open side.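

No step can be read from compound 1 to compound 4, because both values are limits and not numbers: the limit of > 100 ug/mL in this assay, at which 4 of the 4 values shown sit. The compounds shown leave open whether isopropoxy in place of chloro on an aromatic carbon changes the strength of inhibition at all.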